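Amide ring swap on a shared core: morpholine replaces piperazine

This account rests on a few compounds, and the source may have more. Where it says the series, first, only, none or still open, it means among the compounds named here.

Measured compounds:
compound 1 `COc1cc2c(cc1OC)C(CC(=O)N(C)C)CC2` 23.3%
compound 2 `COc1cc2c(cc1OC)C(CC(=O)N1CCCCC1)CC2` 40%
compound 3 `COc1cc2c(cc1OC)C(CC(=O)N1CCNCC1)CC2` 65%

In a functional assay on the whole organism (strain Wistar) for inhibition, with Rattus norvegicus as the target, read by paw edema, with stated times of 60 min and 24 h, at a dose of 100 mg/kg by the oral route (on this read-out lower numbers stand for less inhibition and higher numbers for more inhibition at the one dose given (going by the name of the read-out)), compound 3 stands highest of the three, with compound 2 nearest and compound 1 furthest. The steps of a number 25 percentage points higher from compound 2 to compound 3 (beyond the scatter) and a number 41.7 percentage points higher from compound 1 to compound 3 (beyond the scatter) both point to the piperazin-1-yl as the feature setting compound 3 apart. Compound 4 `COc1cc2c(cc1OC)C(CC(=O)N1CCOCC1)CC2` carries the change (morpholin-4-yl in place of piperazin-1-yl on a carbonyl carbon). The step that bears most on this is a number 25 percentage points higher from compound 2 to compound 3 (beyond the scatter), since piperidin-1-yl and morpholin-4-yl both lack the hydrogen-bond donor that piperazin-1-yl brings. Compound 4 is therefore expected to fall below compound 3 by a number 23 percentage points lower from compound 3 to compound 4 (beyond the scatter), back toward the level of compound 2. The estimate for compound 4 in this assay is 42%, with a range from 25% to 60%.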

Compound 4, a percentage reported as inhibition, in the whole organism at one dose (the size of the read-out at that dose, not a potency): 23.3%
For compound 4 the middle estimate is 18.7 percentage points above the measured one; the whole stated range lies above it.
By their numbers in this assay, from the lowest: compounds 1 and 4 (each within the scatter of the next); then compound 2; then compound 3.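

At this carbonyl carbon in this assay, the six-membered rings are not interchangeable: morpholin-4-yl gives a number 41.7 percentage points lower from compound 3 to compound 4 (beyond the scatter) and a number 16.7 percentage points lower from compound 2 to compound 4 (beyond the scatter). Having a ring in this place is thus not enough: the swap from dimethylamino gives no change at the digits printed from compound 1 to compound 4 (within the scatter). Nothing measured here accounts for these steps. Still open, as far as these compounds go, is how 4-methylpiperazin-1-yl or thiomorpholin-4-yl would read in the same place on the shared core.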